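The source may report more compounds than this note shows. Statements on the series, on what has been measured and on what is new or still open speak of the compounds shown alone.

Measured compounds:
- compound 1, `CC(C)N[C@H](C(=O)Nc1cc2cc[nH]c(=O)c2cc1Cl)C1CCCCC1`, gives 190 nM in a functional assay (aorta) with Rattus norvegicus as the target; on this read-out higher numbers stand for an effect only at larger amounts of compound and lower numbers for an effect already at smaller amounts.
- compound 2, `CC(C)[C@H](N)C(=O)Nc1cc2cc[nH]c(=O)c2cc1Cl`, gives 500 nM in this assay.
- compound 3, `O=C(Nc1cc2cc[nH]c(=O)c2cc1Cl)[C@@H]1CCCN1`, has "not determined" (no result reported) in this assay, so no result is reported for it.

Compound 1 holds the lowest of the two numbers in this assay; compound 2 stands at a higher number, and that gap lies beyond the usual scatter. Within the data shown here, compound 1 and compound 2 differ in more than one place, so no single step between them can be read off, and compound 3 adds no number.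

Compound 4, `N[C@H](C(=O)Nc1cc2cc[nH]c(=O)c2cc1Cl)C1CCCCC1`, is not yet measured. It differs from compound 1 by hydrogen in place of isopropyl on an amine nitrogen. Among the measured compounds shown here, no pair of measured compounds shows this change alone, so the direction rests on the two values at hand: compound 2, which also carries a free amine, sits at the higher number, while compound 1, with the isopropyl on the amine nitrogen, sits at the lower one. A modest move toward higher numbers is therefore expected for compound 4, as a 2.1-fold higher number from compound 1 to compound 4 (0.32 log units; beyond the scatter), although a result within the scatter would not surprise. The estimate for compound 4 in this assay is 400 nM, with a range from 150 nM to 1100 nM.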

Compound 4, half-maximal effective concentration: 180 nM
For compound 4 the middle estimate is 2.2-fold (0.35 log units) above the measured one; low and high end bracket the measured number.
By their numbers in this assay, from the lowest: compounds 4 and 1 (each within the scatter of the next); then compound 2.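

In this assay the substituent on the amine nitrogen makes no readable difference here: with hydrogen in place of isopropyl there is a 1.1-fold lower number from compound 1 to compound 4 (0.02 log units; within the scatter), so the two stand level. The readable change lies instead on the saturated chain carbon bound to an amine nitrogen and a carbonyl carbon, where cyclohexyl in place of isopropyl gives a 2.8-fold lower number from compound 2 to compound 4 (0.44 log units; beyond the scatter), a modest step with the free amine held constant. The data shown offer no explanation for either step.

Steps involving compound 3 cannot be read, as it has no number. Open questions are whether a phenyl or a tert-butyl group on that chain carbon goes beyond cyclohexyl, and whether a methyl or an acetyl group on the amine nitrogen also stands level with hydrogen and isopropyl.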